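Moving the fluorine around the phenoxy ring in a coumarin series

This account rests on a few compounds, and the source may have more. Where it says the series, first, only, none or still open, it means among the compounds named here.

Measured compounds:
- compound 1, `Cc1ccc(Oc2c(/C=N\CCCCCOc3cc4oc(=O)cc(C)c4cc3Cl)c(C)nn2C)cc1`: 7970 nM in a functional assay on U-87MG ATCC cells for antiproliferative activity against U-87 MG (Homo sapiens), read by MTT assay, with a stated time of 72 h; a higher number here means a weaker inhibitor, a lower number a stronger inhibitor
- compound 2, `Cc1nn(C)c(Oc2ccccc2F)c1/C=N\CCCCCCOc1cc2oc(=O)cc(C)c2cc1Cl`: > 25000 nM in this assay

Compound 1, the shorter-chain member with a 4-methylphenoxy group, gives a half-maximal inhibitory concentration of 7970 nM in this assay. Compound 2 carries a 2-fluorophenoxy group and a longer chain, and in this assay compound 2 reaches only the limit of > 25000 nM, which is the edge of what the assay can report rather than a number. Compound 2 therefore stands at the weak end of the two measured compounds, sitting on (the limit of > 25000 nM in this assay, at which 1 of the 2 values shown sits).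

Compound 3, `Cc1nn(C)c(Oc2cccc(F)c2)c1/C=N\CCCCCCOc1cc2oc(=O)cc(C)c2cc1Cl`, has not yet been measured. It differs from compound 2 only in the position of the fluorine: 3-fluorophenyl in place of 2-fluorophenyl on an oxygen on an aromatic ring. Going by the values given here, because no two measured compounds differ in one place, no measured step gives a guide to the size of such a move. The expectation is that the change is small, within the scatter or a little beyond it, so compound 3 is estimated at 20000 nM, with a range from 7000 nM to 60000 nM, an expected step of an at least 1.2-fold lower number from compound 2 to compound 3 (0.09 log units; that floor lies within the scatter).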

Compound 3, half-maximal inhibitory concentration: > 25000 nM
Compound 3: a limit, no number; the forecaster's own chance of this, stated with the estimate: 55%; at least 1.2-fold (0.09 log units) between middle value and limit.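

In this assay compound 3 gives > 25000 nM, which is a limit and not a number. Compound 2 also stands at a limit, so no step can be read from compound 2 to compound 3. As far as these compounds go, what stays open is how far either compound lies past its limit, and so whether 3-fluorophenyl and 2-fluorophenyl differ at all here.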